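Compound 3: an estimate built on a limit

A few compounds are considered here, and "the series" means these few. Any claim that something is new, unique, unknown or untested is made for them only; others in the source may bear on it.

Compound 1 `O=C(O)c1cccc(S(=O)(=O)N2CCC(NS(=O)(=O)c3cc(S(=O)(=O)c4ccccc4)ccc3C(F)(F)F)CC2)c1`: 0.383 h
Compound 2 `O=C(C1CCNCC1)N1CCC(NS(=O)(=O)c2cc(S(=O)(=O)c3ccccc3)ccc2C(F)(F)F)CC1`: > 0.5 h

In an in vitro ADME assay on microsomes from liver (Rattus norvegicus) for metabolic stability, tested at 1 uM (a higher number here means that the compound lasts longer, a lower number that the compound disappears faster), compound 2 gives > 0.5 h, which is a limit and not a number. So its true position is not known exactly.

Compound 3 `O=C(CC1CCNCC1)N1CCC(NS(=O)(=O)c2cc(S(=O)(=O)c3ccccc3)ccc2C(F)(F)F)CC1` differs from compound 2 in one place: (piperidin-4-yl)methyl in place of piperidin-4-yl on a carbonyl carbon. The ring stays the same, and (piperidin-4-yl)methyl takes the place of piperidin-4-yl on a carbonyl carbon.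

Among the measured compounds shown here, only one measured step bears on this, an at least 1.3-fold higher number from compound 1 to compound 2 (0.11 log units; that floor lies within the scatter). It exchanges a different pair of groups, and its floor lies within the scatter, so it gives no measured size for the present change. No step beyond the scatter is therefore expected in this assay, and no direction can be favoured. The expected step is a step that the limit leaves unreadable from compound 2 to compound 3. For compound 3 the estimate is 0.55 h, with an expected range from 0.25 h to 1.2 h.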

Compound 3, half-life: > 0.5 h
Compound 3 ended at the assay's limit (the forecaster's own chance of this, stated with the estimate: 55%); the middle value lies beyond the limit too.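

In this assay, compound 3 stays at the same limit as compound 2, so on a carbonyl carbon (piperidin-4-yl)methyl in place of piperidin-4-yl does not bring the half-life down to a readable number. The size of the step between these two compounds cannot be read, because both values are limits and not numbers: the limit of > 0.5 h in this assay, at which 2 of the 3 values shown sit.

Putting ((piperidin-4-yl)methyl)carbonyl in place of (3-carboxyphenyl)sulfonyl on the ring nitrogen gives an at least 1.3-fold higher number from compound 1 to compound 3 (0.11 log units; that floor lies within the scatter), so a real gain over the acid-bearing compound is not established.

Going by these compounds, how far the true half-lives of compound 2 and compound 3 lie past the limit remains open. So does whether a longer chain on the carbonyl carbon, or a carboxylic acid on the piperidine ring, would also stay at that limit.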